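Three Close Neighbours and an Untested 2-Methylphenyl Group

The source may hold more compounds than are shown below. What is called first, only, known or untested is meant among the compounds shown, and "the series" means these compounds.

Measured so far in a functional assay on A549 cells (Homo sapiens) for cytotoxicity; a higher number here means that more compound is needed for the effect, a lower number that less compound is needed:
- compound 1 `COC1=C(C)C(=O)/C(=C(O)/C=C/c2cccc(OC)c2)C(=O)C1(C)C` gives 2.8 ug/mL
- compound 2 `COC1=C(C)C(=O)/C(=C(O)/C=C/c2ccc(O)cc2)C(=O)C1(C)C` gives 3.1 ug/mL
- compound 3 `COC1=C(C)C(=O)/C(=C(O)/C=C/c2ccc(F)cc2)C(=O)C1(C)C` gives 3.3 ug/mL

These three compounds share one core and differ only in the group on a double-bonded chain carbon. Compound 3 stands level with the other two, as a 1.1-fold higher number from compound 2 to compound 3 (0.03 log units; within the scatter) and a 1.2-fold higher number from compound 1 to compound 3 (0.07 log units; within the scatter) both show. Compound 4 `COC1=C(C)C(=O)/C(=C(O)/C=C/c2ccccc2C)C(=O)C1(C)C` differs from compound 3 in a single group, and 2-methylphenyl in place of 4-fluorophenyl on a double-bonded chain carbon bound to a double-bonded chain carbon gives the count of that exchange: 2-methylphenyl in place of 4-fluorophenyl. Within the data shown here, the steps that bear on it are those that exchanged a group at this same place, namely a 1.1-fold higher number from compound 1 to compound 2 (0.04 log units; within the scatter) and a 1.2-fold higher number from compound 1 to compound 3 (0.07 log units; within the scatter) and the step to compound 3 from compound 2 already given. Among the measured compounds shown here, no measured compound carries a 2-methylphenyl group, so this group remains untested and some uncertainty stays. With steps as small as a 1.1-fold higher number from compound 2 to compound 3 (0.03 log units; within the scatter) at this place, no step beyond the scatter is expected in this assay for compound 4. The estimate amounts to a 1.1-fold lower number from compound 3 to compound 4 (0.04 log units; within the scatter) as the expected step. For compound 4 the estimated value is 3 ug/mL with an expected range of 1.8 ug/mL to 5 ug/mL in this estimate.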

Compound 4, concentration for half-maximal effect: 4.6 ug/mL
Estimate against measurement, compound 4: 1.5-fold (0.19 log units) below; measured number inside the range.
By their numbers in this assay, from the lowest: compounds 1, 2, 3 and 4 (each within the scatter of the next).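

In this assay the exchange of 4-fluorophenyl for 2-methylphenyl gives a 1.4-fold higher number from compound 3 to compound 4 (0.14 log units; within the scatter) and the same group gives a 1.5-fold higher number from compound 2 to compound 4 (0.17 log units; within the scatter) when it replaces 4-hydroxyphenyl, while its replacement of 3-methoxyphenyl gives a 1.6-fold higher number from compound 1 to compound 4 (0.22 log units; within the scatter) and so completes the set of comparisons. The three earlier aromatic groups each carried a fluorine or oxygen atom, whereas 2-methylphenyl is built of carbon only, and even this change on a double-bonded chain carbon bound to a double-bonded chain carbon produces no step beyond the scatter, so all four compounds remain level in this measurement. Nothing in the available data gives a reason for these numbers.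

The compounds shown leave open whether a phenyl ring carrying an amine or a carboxylic acid, or a longer carbon chain in place of the ring, would also stay within the scatter at this place. From the compounds shown here alone, all four compounds also keep the shared core unchanged, so the effect in this assay of replacing its methoxy group with, for example, an ethoxy group remains unknown.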